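The compounds below may be only part of what the source reports. "The series", "measured", "known", "first", "only" and "open" are said of these compounds alone.

compound 1 `O=c1[nH]/c(=C\c2c[nH]cn2)c(=O)[nH]/c1=C\c1cccc(Oc2ccc(F)cc2)c1`: 479 nM
compound 2 `O=c1[nH]/c(=C\c2cccc(Oc3ccc(F)cc3)c2)c(=O)[nH]/c1=C\c1ccccc1`: 389 nM
compound 3 `O=c1[nH]/c(=C\c2ccc(Cl)o2)c(=O)[nH]/c1=C\c1cccc(Oc2ccc(F)cc2)c1`: 180 nM

In a functional assay on NCI-H460 cells (Homo sapiens) for cytotoxicity, read by MTT assay, with a stated time of 72 h (on this read-out lower numbers stand for stronger inhibition and higher numbers for weaker inhibition), compound 3 gives 180 nM, the lowest of the three numbers. The three compounds differ only in the group on a double-bonded chain carbon bound to an aromatic carbon. Compound 4 `O=c1[nH]/c(=C\c2nc3ccccc3[nH]2)c(=O)[nH]/c1=C\c1cccc(Oc2ccc(F)cc2)c1`, not yet measured, changes that same group, with 1H-benzimidazol-2-yl in place of 5-chlorofuran-2-yl on a double-bonded chain carbon bound to an aromatic carbon.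

Among the measured compounds shown here, three measured steps bear on this change. Two of them arrive at the 5-chlorofuran-2-yl group, and both are modest: a 2.7-fold lower number from compound 1 to compound 3 (0.43 log units; beyond the scatter), and a 2.2-fold lower number from compound 2 to compound 3 (0.33 log units; beyond the scatter). The third, a 1.2-fold lower number from compound 1 to compound 2 (0.09 log units; within the scatter), shows no clear difference between the two groups that replace it. For the measured compounds named here, both known replacements of 5-chlorofuran-2-yl therefore give a higher number, but no measured compound carries 1H-benzimidazol-2-yl. A modest rise in this assay is expected, of similar size to those two steps, and the expected step is a 1.7-fold higher number from compound 3 to compound 4 (0.22 log units; within the scatter). For compound 4 the estimate is 300 nM, with an expected range of 120 nM to 750 nM.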

Compound 4, half-maximal inhibitory concentration: > 1000 nM
Compound 4: a limit, no number (the forecaster's own chance of this, stated with the estimate: 3%); middle value at least 3.3-fold (0.52 log units) away from the limit.
By their numbers in this assay, from the lowest: compound 3; then compounds 2 and 1 (each within the scatter of the next). At a limit, above all of these: compound 4.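

In this assay, compound 4 gives only a limit, not a number: the limit of > 1000 nM in this assay, at which 1 of the 4 values shown sits. Even so, the limit is enough to place it, since 1H-benzimidazol-2-yl on this double-bonded chain carbon gives an at least 5.5-fold higher number from compound 3 to compound 4 (0.74 log units; beyond the scatter), an at least 2.5-fold higher number from compound 2 to compound 4 (0.41 log units; beyond the scatter) and an at least 2.0-fold higher number from compound 1 to compound 4 (0.31 log units; beyond the scatter), all beyond the scatter. Among the compounds shown here, the earlier compounds showed only modest steps at this position, whereas this change shows that one group can lift the number clear of all three others, and its true size remains unknown.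

The change swaps a single five-membered aromatic ring for a fused pair and adds a hydrogen-bond donor, and the compounds shown do not separate these two differences. As far as these compounds go, how a pyridine ring or an amine at this position would read also remains open.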